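This account rests on a few compounds, and the source may have more. Where it says the series, first, only, none or still open, it means among the compounds named here.

Measured compounds:
- compound 1 `O=C(NO)c1ccc2c(c1)CCN(S(=O)(=O)c1cc(F)c(F)c(F)c1F)C2`: 50.4 nM
- compound 2 `O=C(NO)c1ccc(CN(C2CC2)S(=O)(=O)c2cc(F)c(F)c(F)c2F)cc1`: 8.5 nM
- compound 3 `CC(C)N(Cc1ccc(C(=O)NO)cn1)S(=O)(=O)c1cc(F)c(F)c(F)c1F`: 121 nM

All three were run in an assay on Sf9 cells for inhibition of protein deacetylase HDAC6 (Homo sapiens), read by fluorescence and mobility shift assay; on this read-out higher numbers stand for weaker inhibition and lower numbers for stronger inhibition. Compound 2 gives the lowest number of the three; compound 1 sits higher, and compound 3 higher still, both gaps beyond the usual scatter of this assay. For the measured compounds named here, the three share the hydroxamic acid and the tetrafluorophenylsulfonyl group and differ in the linker and in the substituent on the sulfonamide nitrogen, but no pair differs in one place only, so the separate values are all that can be read.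

Compound 4 `COCCN(Cc1ccc(C(=O)NO)cc1)S(=O)(=O)c1cc(F)c(F)c(F)c1F` has not been measured. It differs from compound 2 in one place: 2-methoxyethyl in place of cyclopropyl on a sulfonamide nitrogen. Both substituents are small and uncharged; the entering group adds one hydrogen-bond acceptor and loses the ring. Going by the values given here, with no step of this kind among the measured compounds, the expectation rests on compound 2 alone and on the view that an open chain of this size should not move the number far. The step from compound 2 to compound 4 is expected to be a slight move toward a higher number, a 2.0-fold higher number from compound 2 to compound 4 (0.30 log units; within the scatter), close to the scatter. Compound 4 is therefore estimated at 17 nM, with a likely range from 7 nM to 45 nM.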

Compound 4, half-maximal inhibitory concentration: 27.8 nM
The estimate for compound 4 lay 1.6-fold (0.21 log units) below the measured number; the measured number falls inside the stated range.
By their numbers in this assay, from the lowest: compound 2; then compounds 4 and 1 (each within the scatter of the next); then compound 3.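

The sulfonamide nitrogen now has its first one-place comparison: in this assay, 2-methoxyethyl in place of cyclopropyl gives a modest step (a 3.3-fold higher number from compound 2 to compound 4 (0.51 log units; beyond the scatter)), beyond the scatter. This position therefore responds to the change, though the step remains modest and the open chain is accepted on the shared core. The change removes the ring and adds a hydrogen-bond acceptor in one move, and no measured data here separate those two differences or explain the step.

A plain butyl chain or a cyclobutyl ring on the same nitrogen would help show whether the ring or the ether oxygen accounts for the step. On these data alone, it also remains open how a terminal amine or carboxylic acid on this chain would read, and whether the step carries over to the other cores.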